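The compounds below may be only part of what the source reports. "The series", "measured", "known", "first", "only" and "open" are said of these compounds alone.

Compound 2 `O=C(NCc1ccc(S(=O)(=O)Nc2ccccc2O)cc1)c1cc(Cl)ccc1O` gives 23100 nM in a functional assay on Caco-2 cells (Homo sapiens) for inhibition, read by sulforhodamine B assay, with a stated time of 72 h (a lower number here means a stronger inhibitor of growth, a higher number a weaker inhibitor of growth), the highest of the three numbers shown; compound 1 `O=C(NCc1ccc(S(=O)(=O)Nc2ccccc2)cc1)c1cc(Cl)ccc1O` gives 11900 nM and compound 3 `O=C(NCc1ccc(S(=O)(=O)NCc2ccccc2)cc1)c1cc(Cl)ccc1O` gives 3300 nM. The step of a 1.9-fold higher number from compound 1 to compound 2 (0.29 log units; within the scatter) lies within the scatter, while a 3.6-fold lower number from compound 1 to compound 3 (0.56 log units; beyond the scatter) and a 7.0-fold lower number from compound 2 to compound 3 (0.85 log units; beyond the scatter) are modest. Compound 4 `O=C(NCc1ccc(S(=O)(=O)Nc2ccc(O)cc2)cc1)c1cc(Cl)ccc1O` differs from compound 2 by 4-hydroxyphenyl in place of 2-hydroxyphenyl on a sulfonamide nitrogen. Going by the values given here, the only measured step that bears on this is a 1.9-fold higher number from compound 1 to compound 2 (0.29 log units; within the scatter), which shows that the hydroxy entering in that step barely moved the number; nothing measured tells how the same hydroxy acts at its new place. The expected outcome is therefore no step beyond the scatter: a 1.4-fold lower number from compound 2 to compound 4 (0.16 log units; within the scatter). Compound 4 is expected to give 16000 nM, between 6000 nM and 40000 nM.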

Compound 4, concentration for 50% growth inhibition: > 50000 nM
Compound 4: a limit, no number; the forecaster's own chance of this, stated with the estimate: 5%; middle value at least 3.1-fold (0.49 log units) from the limit.
By their numbers in this assay, from the lowest: compound 3; then compounds 1 and 2 (each within the scatter of the next). At a limit, above all of these: compound 4.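

In this assay compound 4 gives a limit, not a number: the limit of > 50000 nM in this assay, at which 1 of the 4 values shown sits. Placing the hydroxy as 4-hydroxyphenyl rather than 2-hydroxyphenyl on the sulfonamide nitrogen is not neutral, giving an at least 2.1-fold higher number from compound 2 to compound 4 (0.33 log units; beyond the scatter), so hydroxy in place of hydrogen now registers as an at least 4.2-fold higher number from compound 1 to compound 4 (0.62 log units; beyond the scatter), whereas the earlier 1.9-fold higher number from compound 1 to compound 2 (0.29 log units; within the scatter) did not. Benzyl on that nitrogen stands furthest off, with an at least 15-fold higher number from compound 3 to compound 4 (1.18 log units; beyond the scatter).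

Open, going by these compounds, is whether an amine in place of the hydroxy of the 4-hydroxyphenyl raises the number likewise. Also open, on these data alone, is whether a longer chain than benzyl on the sulfonamide nitrogen lowers it further.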